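A few compounds are considered here, and "the series" means these few. Any claim that something is new, unique, unknown or untested is made for them only; others in the source may bear on it.

Working notes on the series. In a functional assay on HL-60 cells (Homo sapiens) for inhibition, read by CCK-8 assay, with a stated time of 48 h (on this read-out lower numbers stand for stronger inhibition and higher numbers for weaker inhibition), compound 1 `O=S(=O)(NCCNC(=S)Nc1cccc(Cl)c1)c1ccc(-c2ccccc2OCc2cccc(O)c2)s1` gives 1800 nM and compound 3 `COc1ccc(Oc2ccc(C(C)C)cc2-c2ccsc2S(=O)(=O)NCCNC(=O)Nc2cc(Cl)cc(Cl)c2)cc1OC` gives 6500 nM. Compound 2 `O=C(NCCNS(=O)(=O)c1ccc(-c2ccccc2O[C@H]2CC[C@@H](O)CC2)s1)Nc1ccc([N+](=O)[O-])cc1` gives > 20000 nM, and this is a limit of the assay, not a number. Its position is therefore known only as a limit, and it has no measured neighbour in the series.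

Compound 4 `O=C(NCCNS(=O)(=O)c1ccc(-c2ccccc2O[C@H]2CC[C@H](O)CC2)s1)Nc1ccc([N+](=O)[O-])cc1` is related to compound 2 by the two compounds have the same atoms and bonds and differ only in configuration as drawn: 2 of 2 stereo elements differ (all stereocentres are inverted: mirror images); a stereocentre at a saturated ring carbon is drawn s in compound 2 and r in compound 4; a stereocentre at a saturated ring carbon is drawn s in compound 2 and r in compound 4: the two have the same atoms and bonds, and all stereocentres are inverted, so they are drawn as mirror images. Among the compounds with values here, no measured pair shows the effect of such an inversion. In this assay, no step beyond the usual scatter is therefore expected, and no direction is favoured. The expectation rests on the limit for compound 2, > 20000 nM. The expected step is an at least 1.2-fold lower number from compound 2 to compound 4 (0.09 log units; that floor lies within the scatter), and a limit is also a likely outcome. For compound 4 the estimated value is 16000 nM, with an expected range of 6000 nM to 30000 nM.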

Compound 4, half-maximal inhibitory concentration: 8900 nM
The estimate for compound 4 lay 1.8-fold (0.25 log units) above the measured number; measured number inside the range.
By their numbers in this assay, from the lowest: compound 1; then compounds 3 and 4 (each within the scatter of the next). At a limit, above all of these: compound 2.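

In this assay, within the data shown here, inverting both stereocentres at the saturated ring carbons gives an at least 2.2-fold lower number from compound 2 to compound 4 (0.35 log units; beyond the scatter) and is the first readable step, so configuration as drawn can alone move the number at this position beyond the scatter.
Compound 2 stands at a limit, so the size of the step is only a floor: the limit of > 20000 nM in this assay, at which 1 of the 4 values shown sits.
No other change accompanies the inversion, so the step belongs to configuration alone: the fact that compounds 2 and 4 differ only in the configuration as drawn

The compounds shown leave open whether an amine or a carboxylic acid in place of the hydroxyl on the saturated ring of compound 2 and compound 4 would keep a difference between the two configurations. They also leave open how large the step really is, and whether the same inversion counts with a thiourea in place of the urea.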